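Extending the Methyl to Butyl on a Sulfonyl Series

A few compounds are considered here, and "the series" means these few. Any claim that something is new, unique, unknown or untested is made for them only; others in the source may bear on it.

Values in a functional assay (aorta) with Rattus norvegicus as the target; on this read-out lower numbers stand for stronger inhibition and higher numbers for weaker inhibition:
Compound 1 `CCN(CC)CCCOc1ccc(S(=O)(=O)c2c(C)cn3ccccc23)cc1`: 3390 nM
Compound 2 `CCCCN(CCCC)CCCCOc1ccc(S(=O)(=O)c2c(C(C)C)cn3ccccc23)cc1`: 20.2 nM
Compound 3 `CCCN(CCC)CCCOc1ccc(S(=O)(=O)c2c(C)cn3ccccc23)cc1`: 957 nM

Among these three, compound 3 at 957 nM holds the second highest number in this assay. The next analogue, compound 4 `CCCCc1cn2ccccc2c1S(=O)(=O)c1ccc(OCCCN(CCC)CCC)cc1`, differs from compound 3 in one place: propyl in place of hydrogen on a saturated chain carbon bound to an aromatic carbon. This puts propyl in place of hydrogen on a saturated chain carbon bound to an aromatic carbon, which also reads as methyl to butyl.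

Within the data shown here, the only measured single change is a 3.5-fold lower number from compound 1 to compound 3 (0.55 log units; beyond the scatter). It lies at the amine end of the molecule, not at the place now altered, so it offers only a rough scale. Among the measured compounds shown here, no measured step isolates the new change. Compound 2 reaches 20.2 nM, but it differs from compound 3 in several places at once, so its value cannot be assigned to any one of them. Even so, that value leaves room for a lower number, and a modest-to-moderate fall is expected. The expected step is a 4.8-fold lower number from compound 3 to compound 4 (0.68 log units; beyond the scatter). For compound 4 the estimated value is 200 nM, within an expected range of 50 nM to 700 nM.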

Compound 4, half-maximal inhibitory concentration: 570 nM
Beside the measured number, compound 4's estimate is 2.9-fold (0.45 log units) below it; the range from low to high includes it.
By their numbers in this assay, from the lowest: compound 2; then compounds 4 and 3 (each within the scatter of the next); then compound 1.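

In this assay the change of methyl to butyl gives a 1.7-fold lower number from compound 3 to compound 4 (0.23 log units; within the scatter) and so cannot be told apart from repeat measurement. Among these compounds, this is the first reading at this place on the shared core, and it differs from the only earlier single change, at the amine end, which gave a 3.5-fold lower number from compound 1 to compound 3 (0.55 log units; beyond the scatter) and lies beyond the scatter. No measured property is available that bears on this result.

Still open, on these data alone, is whether a longer chain such as hexyl, or a phenyl ring, at this place would give a step beyond the scatter. Also open, as far as these compounds go, is whether butyl in place of methyl would give a similar step with a different amine, such as pyrrolidine, at the end of the chain.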